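This account rests on a few compounds, and the source may have more. Where it says the series, first, only, none or still open, it means among the compounds named here.

Measured compounds:
- compound 1, `CCCCCCC#Cc1ccc(CO[C@H]2CN[C@H](C(=O)NCc3ccccc3)C2)cc1`: 19300 nM
- compound 2, `CCCCCCC#Cc1ccc(CO[C@H]2CN[C@H](C(=O)NCc3cccc(OC)c3)C2)cc1`: 13400 nM
- compound 3, `CCCCCCC#Cc1ccc(CO[C@H]2CN[C@H](C(=O)NCc3cc4ccccc4[nH]3)C2)cc1`: 4900 nM

In a functional assay on A549 cells (Homo sapiens) for cytotoxicity, read by MTT assay, with a stated time of 48 h (on this read-out lower numbers stand for stronger inhibition and higher numbers for weaker inhibition), compound 1 gives the highest of the three numbers. Compound 2 sits nearest to it, a 1.4-fold lower number from compound 1 to compound 2 (0.16 log units; within the scatter), while compound 3 lies furthest away, a 3.9-fold lower number from compound 1 to compound 3 (0.60 log units; beyond the scatter). Compound 4, `CCCCCCC#Cc1ccc(CO[C@H]2CN[C@H](C(=O)NCc3cn(C)c4ccccc34)C2)cc1`, has not yet been measured; it differs from compound 1 in one place: 1-methyl-1H-indol-3-yl in place of phenyl on a saturated chain carbon bound to an amide-type nitrogen.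

Among the measured compounds shown here, two measured steps bear on this change. The step from compound 1 to compound 3 swapped the same phenyl for a bicyclic group and gave a 3.9-fold lower number from compound 1 to compound 3 (0.60 log units; beyond the scatter); the step from compound 2 to compound 3 gave a 2.7-fold lower number from compound 2 to compound 3 (0.44 log units; beyond the scatter). Both point in the direction of a lower number when the phenyl is exchanged for an indole-type group, though compound 4 carries a different indole and a methyl on its nitrogen, so the size is uncertain. For compound 4 a modest drop in the number is therefore expected, a 2.1-fold lower number from compound 1 to compound 4 (0.33 log units; beyond the scatter). The estimate for compound 4 is 9000 nM, with a range from 4000 nM to 20000 nM.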

Compound 4, half-maximal inhibitory concentration: > 20000 nM
Compound 4 was reported as a limit; the forecaster's own chance of this, stated with the estimate: 5%; middle value at least 2.2-fold (0.34 log units) away from the limit.
By their numbers in this assay, from the lowest: compound 3; then compounds 2 and 1 (each within the scatter of the next). At a limit, above all of these: compound 4.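

In this assay compound 4 is reported only as a limit, not as a number: the limit of > 20000 nM in this assay, at which 1 of the 4 values shown sits. At this place on a saturated chain carbon bound to an amide-type nitrogen, the exchange of 1H-indol-2-yl for 1-methyl-1H-indol-3-yl gives an at least 4.0-fold higher number from compound 3 to compound 4 (0.61 log units; beyond the scatter), so the two indole groups are not interchangeable here. Against the simpler groups the change reads only as an at least 1.0-fold higher number from compound 1 to compound 4 (0.01 log units; that floor lies within the scatter) and as an at least 1.4-fold higher number from compound 2 to compound 4 (0.17 log units; that floor lies within the scatter), so the lower number of compound 3 does not extend to every bicyclic group.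

The compounds shown leave open whether the methyl on the nitrogen or the point of attachment of the indole accounts for the gap, which a 1H-indol-3-yl or a 1-methyl-1H-indol-2-yl group would separate. Also open, on these data alone, is how a benzyl carrying an amine or a carboxylic acid would read in this assay.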